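From 4-methylphenyl to 3-fluorophenyl at the assay limit

The source may hold more compounds than are shown below. What is called first, only, known or untested is meant among the compounds shown, and "the series" means these compounds.

Measured so far in an ADME assay on L929 cells (Mus musculus) for cytotoxicity, read by resazurin assay, with a stated time of 72 h; a higher number here means a weaker inhibitor, a lower number a stronger inhibitor:
Compound 1 `O=C(/C=C/c1ccc2c(c1)B(O)OC2)c1ccccn1`: > 10 ug/mL
Compound 2 `Cc1ccc(C(=O)/C=C/c2ccc3c(c2)B(O)OC3)cc1`: > 10 ug/mL

Compound 1 gives only a limit, > 10 ug/mL, and not a number. Compound 2 also gives only a limit, > 10 ug/mL. The evidence so far is simply (the limit of > 10 ug/mL in this assay, at which 2 of the 2 values shown sit). Within the data shown here, the one measured step, a step that the two limits leave unreadable from compound 1 to compound 2, offers no size to carry forward. Compound 3 `O=C(/C=C/c1ccc2c(c1)B(O)OC2)c1cccc(F)c1` has 3-fluorophenyl in place of 4-methylphenyl on a carbonyl carbon. No step beyond the scatter is therefore expected in this assay, and no direction can be called. The expected step is a step that the limit leaves unreadable from compound 2 to compound 3. For compound 3 the estimate is 15 ug/mL, with an expected range from 8 ug/mL to 40 ug/mL.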

Compound 3, half-maximal inhibitory concentration: > 10 ug/mL
Compound 3: no number, only a limit (the forecaster's own chance of this, stated with the estimate: 85%); the middle value does not contradict the limit.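

Among these compounds, compound 3 gives only a limit in this assay, as do compound 1 and compound 2, so no step to compound 3 can be read. As far as these compounds go, how strongly each compound inhibits these cells, and whether swapping the group on the carbonyl carbon changes that, stays open.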